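From hydroxy to methoxy at the assay limit

The source may hold more compounds than are shown below. What is called first, only, known or untested is meant among the compounds shown, and "the series" means these compounds.

Of the compounds shown here, two have been measured in a functional assay on M4E cells (Homo sapiens) for cytotoxicity, read by resazurin assay, with a stated time of 72 h (on this read-out higher numbers stand for weaker inhibition and lower numbers for stronger inhibition), so far. Compound 1 (`COc1cc(/C=C/C(=O)OCCCCCCO[N+](=O)[O-])ccc1O`) gives > 50000 nM as its result, which is a limit of the assay and not a number. Compound 2 (`O=C(/C=C/c1ccc(OCCCCCCO[N+](=O)[O-])c(O)c1)OCCCCCCO[N+](=O)[O-]`) gives > 50000 nM as its result, again a limit and not a number. Compound 2 thus stands at the limit of > 50000 nM in this assay, at which 2 of the 2 values shown sit, and has no exact value.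

Compound 3 (`COc1cc(/C=C/C(=O)OCCCCCCO[N+](=O)[O-])ccc1OCCCCCCO[N+](=O)[O-]`) differs from compound 2 by one small edit, hydroxy to methoxy, that is methyl in place of hydrogen on an oxygen on an aromatic ring. Within the data shown here, no measured pair shows this change, so no shift beyond the scatter is expected in this assay for it. The estimated step (a number no higher from compound 2 to compound 3 (the limit leaves the size open)) is therefore expected to be small. Compound 3 is expected at 50000 nM as an estimate, with an expected range from 25000 nM to 100000 nM for it.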

Compound 3, half-maximal inhibitory concentration: > 50000 nM
Compound 3: only a limit was reported (the forecaster's own chance of this, stated with the estimate: 75%); the middle value sits exactly at the limit.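

The steps from compound 2 to compound 3 and from compound 1 to compound 3 in this assay cannot be read, since all three results are limits and not numbers: the limit of > 50000 nM in this assay, at which 3 of the 3 values shown sit.

The compounds shown leave open how strongly any of them inhibits these cells, and whether either edit shifts that strength at all.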